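This account rests on a few compounds, and the source may have more. Where it says the series, first, only, none or still open, it means among the compounds named here.

Values in a functional assay on MCF7 cells (Homo sapiens) for antiproliferative activity, with a stated time of 72 h; on this read-out higher numbers stand for weaker inhibition and lower numbers for stronger inhibition
- compound 1 `COc1cc(OC)c(C(=O)/C=C/c2ccccc2Cl)c(O)c1CN1CCCC1` gives 3900 nM
- compound 2 `COc1cc(OC)c(C(=O)/C=C/c2ccccc2Cl)c(O)c1CN1CCCCC1` gives 2600 nM
- compound 3 `CCN(CC)Cc1c(OC)cc(OC)c(C(=O)/C=C/c2ccccc2Cl)c1O` gives 2700 nM

These three compounds share one core and differ only in the amine group on a saturated chain carbon bound to an aromatic carbon. Compound 2, which carries piperidin-1-yl there, lies within the scatter of both other compounds (a 1.5-fold lower number from compound 1 to compound 2 (0.18 log units; within the scatter)) (a 1.0-fold higher number from compound 2 to compound 3 (0.02 log units; within the scatter)).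

The next compound, compound 4 `COc1cc(OC)c(C(=O)/C=C/c2ccccc2Cl)c(O)c1CN(C)CCCN(C)C`, has (3-(dimethylamino)propyl)(methyl)amino in place of piperidin-1-yl ((3-(dimethylamino)propyl)(methyl)amino in place of piperidin-1-yl on a saturated chain carbon bound to an aromatic carbon). The new group has no ring, as is also true of the diethylamino group of compound 3. The most relevant evidence is therefore the set of earlier amine swaps. Each of them stayed within the scatter, including the swap from compound 1 to diethylamino (a 1.4-fold lower number from compound 1 to compound 3 (0.16 log units; within the scatter)). Among the compounds with values here, no measured compound carries the entering group, however, so these small steps are only a loose guide.

The expectation is therefore no step beyond the scatter in this assay, with a generous margin on either side. The estimated step is small (a 1.2-fold higher number from compound 2 to compound 4 (0.06 log units; within the scatter)). For compound 4 the expected value is 3000 nM, with an estimated range from 1300 nM to 7000 nM.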

Compound 4, half-maximal inhibitory concentration: 3200 nM
For compound 4 the middle estimate is 1.1-fold (0.03 log units) below the measured one; the measured number falls inside the stated range.
By their numbers in this assay, from the lowest: compounds 2, 3, 4 and 1 (each within the scatter of the next).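

In this assay, replacing piperidin-1-yl with (3-(dimethylamino)propyl)(methyl)amino stays within the scatter (a 1.2-fold higher number from compound 2 to compound 4 (0.09 log units; within the scatter)), and the same holds for the steps from the other two amines (a 1.2-fold higher number from compound 3 to compound 4 (0.07 log units; within the scatter); a 1.2-fold lower number from compound 1 to compound 4 (0.09 log units; within the scatter)). Within the data shown here, the earlier compounds showed only that swaps among the first three amines left the number within the scatter, whereas this result extends that flat picture to a longer, ring-free group with 8 heavy atoms and 2 nitrogen atoms, on a saturated chain carbon bound to an aromatic carbon. No measurement available here explains why these four amines give numbers so close together.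

Still open, on these data alone, is whether this position stays equally undemanding with a morpholine ring, a piperazine ring or a carboxylic acid in place of these amines, since each would put different atoms at this spot. As far as these compounds go, it is also open whether a hydroxyl group at the end of a longer chain would stay within the scatter, or whether some group at this position can move the number beyond it in either direction.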